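Trading naphthalen-1-yl for thiophen-2-yl

A few compounds are considered here, and "the series" means these few. Any claim that something is new, unique, unknown or untested is made for them only; others in the source may bear on it.

Of the compounds shown here, two have been measured so far in a functional assay on MCF7 cells (Homo sapiens) for antiproliferative activity, read by MTT assay; a lower number here means a stronger inhibitor, a higher number a weaker inhibitor. In this assay, compound 1 (`COc1ccc([C@@H]2[C@@H](c3ccsc3)C(=O)N2c2cc(OC)c(OC)c(OC)c2)cc1O`) gives 10 nM, while compound 2 (`COc1cc(N2C(=O)[C@H](c3cccs3)[C@H]2c2cccc3ccccc23)cc(OC)c1OC`) gives 620 nM. Compound 2 therefore has the higher of the two numbers, which makes it the weaker inhibitor, and its gap to compound 1 lies beyond the scatter of repeated measurements. These two compounds differ in more than one place, so their gap cannot be tied to any single change.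

Compound 3 (`COc1cc(N2C(=O)[C@H](c3cccs3)[C@H]2c2cccs2)cc(OC)c1OC`) differs from compound 2 in one place: thiophen-2-yl stands in place of naphthalen-1-yl on a saturated ring carbon (thiophen-2-yl in place of naphthalen-1-yl on a saturated ring carbon). Among the compounds with values here, no measured pair shows this swap on its own, so the expectation is a loose one. In this assay, no step beyond the scatter is expected, with only a slight lean towards a weaker inhibitor. The estimated move is a 1.5-fold higher number from compound 2 to compound 3 (0.16 log units; within the scatter). The estimate stays close to compound 2 at 620 nM, its only measured one-place reference point. Compound 3 is expected at 900 nM, with an estimated range of 200 nM to 4000 nM.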

Compound 3, half-maximal inhibitory concentration: 910 nM
Compound 3: middle estimate off by 1.0-fold (0.00 log units), on the low side; the range from low to high includes it.
By their numbers in this assay, from the lowest: compound 1; then compounds 2 and 3 (each within the scatter of the next).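

On the saturated ring carbon next to the ring nitrogen, replacing naphthalen-1-yl (10 heavy atoms, 2 six-membered aromatic rings of carbon only) with thiophen-2-yl (5 heavy atoms, one five-membered aromatic ring with 1 hetero atom) gives a 1.5-fold higher number from compound 2 to compound 3 (0.17 log units; within the scatter) in this assay on the shared core. Within the data shown here, this is the first one-place comparison at this position, and it shows that, for this pair, these two quite different aromatic groups cannot be told apart in this measurement, despite the difference in their heavy-atom counts. Nothing shown explains why the two compounds read so alike.

As far as these compounds go, with only these two groups compared here, it remains open how this position would respond to a non-aromatic group such as an amine, a carboxylic acid or a longer chain. Compound 1 at 10 nM differs from both compound 2 and compound 3 in more than one place, so which of its differences accounts for its much lower number also remains unresolved.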